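The source may hold more compounds than are shown below. What is called first, only, known or untested is meant among the compounds shown, and "the series" means these compounds.

Of the compounds shown here, two built on one shared core have been tested in an assay on HEK293 cells for displacement of a labelled ligand from prostaglandin D2 receptor 2 (Homo sapiens); a lower number here means a stronger inhibitor, a higher number a weaker inhibitor. Compound 1 `CCOC(=O)CCSc1nc2ccccc2n1CC(=O)O` gives 11400 nM. Compound 2 `COc1ccc(CSc2nc3ccccc3n2CC(=O)O)cc1` gives 210 nM, the lower of the two numbers, and its gap to compound 1 lies beyond the usual scatter of this assay. Compound 3 `Cc1ccc(CSc2nc3ccccc3n2CC(=O)O)cc1` has not yet been measured; it differs from compound 2 in one place: methyl in place of methoxy on an aromatic carbon. Among the compounds with values here, no pair of measured compounds shows a change of this kind, so nothing here tells how a swap of methoxy for methyl moves the number in this assay. The change is small, and the expected step is modest, in either direction, or none beyond the scatter. For compound 3 the expected value is 300 nM, with a range from 100 nM to 900 nM. The step that this estimate means for compound 3 is a 1.4-fold higher number from compound 2 to compound 3 (0.15 log units; within the scatter).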

Compound 3, half-maximal inhibitory concentration: 220 nM
The estimate for compound 3 lay 1.4-fold (0.13 log units) above the measured number; low and high end bracket the measured number.
By their numbers in this assay, from the lowest: compounds 2 and 3 (each within the scatter of the next); then compound 1.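

In this assay, methyl in place of methoxy on this aromatic carbon, para to a large group, gives a 1.0-fold higher number from compound 2 to compound 3 (0.02 log units; within the scatter) and so leaves the number unmoved: the oxygen and the one hydrogen-bond acceptor that go with methoxy can be lost here without a change beyond the scatter. The larger change lies elsewhere on the molecule, as 4-methylphenyl in place of (ethoxycarbonyl)methyl on the saturated chain carbon bound to the sulfur gives a 52-fold lower number from compound 1 to compound 3 (1.71 log units; beyond the scatter) in this assay and holds with methyl on the ring. No supporting data shown here explain either step.

On these data alone, only methoxy and methyl appear on this aromatic carbon, so it remains open how a chlorine atom, an amine or a longer chain there would move the number. As far as these compounds go, it is also open whether a bare hydrogen at that carbon would give a similar value.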